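The source may report more compounds than this note shows. Statements on the series, on what has been measured and on what is new or still open speak of the compounds shown alone.

Measured so far:
- compound 1, `CSc1ccc(/C=N/n2c(Cc3ccc(S(C)(=O)=O)cc3)n[nH]c2=S)cc1`: 32.7%
- compound 2, `CS(=O)(=O)c1ccc(Cc2n[nH]c(=S)n2/N=C/c2ccc(Cl)cc2)cc1`: 47.5%
- compound 3, `CS(=O)(=O)c1ccc(Cc2n[nH]c(=S)n2/N=C/c2ccc(F)cc2)cc1`: "not active" (no number reported)

Three compounds share one core and differ only in the group on an aromatic carbon, para to a large group. In a functional assay on HeLa cells (Homo sapiens) for cytotoxicity, read by MTT assay, with a stated time of 48 h, tested at 25 uM (a lower number here means a weaker effect, a higher number a stronger effect of the compound at the concentration tested), compound 1 gives 32.7% and compound 2 gives 47.5%. Compound 3 is reported in this assay as "not active" (no number reported), with no number given, so it stands at the bottom of this small set, without a figure to place it.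

Compound 4, `CS(=O)(=O)c1ccc(Cc2n[nH]c(=S)n2/N=C/c2ccc(-c3ccccc3)cc2)cc1`, is not yet measured. It differs from compound 3 in one place: phenyl in place of fluoro on an aromatic carbon. Going by the values given here, the only measured step in this set, a number 14.8 percentage points higher from compound 1 to compound 2 (beyond the scatter), concerns the same position but exchanges two small groups, neither of them phenyl, so it bears on the step from compound 3 to compound 4 only loosely, showing that a change at this position can move the read-out by a modest amount. Because compound 3 gives "not active" (no number reported) while compound 1 lies at 32.7% and compound 2 lies at 47.5%, a modest rise from compound 3 is expected, with wide uncertainty. Compound 4 is therefore estimated at 28%, within a range from 5% to 55%.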

Compound 4, a percentage reported as activity, at one concentration (the size of the read-out at that concentration, not a potency): 37.3%
The estimate for compound 4 lay 9.3 percentage points below the measured number; the range from low to high includes it.
By their numbers in this assay, from the lowest: compounds 1 and 4 (each within the scatter of the next); then compound 2.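

In this assay, phenyl in place of fluoro on this aromatic carbon goes with a change from compound 3, at "not active" (no number reported), to compound 4, at 37.3%, so a whole aromatic ring at this position still allows a measurable effect on the cells. The read-out does not simply rise with the number of heavy atoms in the group: there is a number 10.2 percentage points lower from compound 2 to compound 4 (beyond the scatter), so chloro stays ahead of phenyl here, while a number 4.6 percentage points higher from compound 1 to compound 4 (within the scatter), which means phenyl and methylsulfanyl cannot be told apart in this assay. No measurement among these data explains why these groups differ in their effect.

The compounds shown leave open how an amine, a carboxylic acid or a longer alkyl chain at this position would compare with chloro and phenyl. Each figure also comes from a single concentration, so it gives the size of the effect at that concentration and leaves the potency of these compounds unsettled.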